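From 3-methoxyphenyl to 4-methoxyphenyl on the shared core

The source may report more compounds than this note shows. Statements on the series, on what has been measured and on what is new or still open speak of the compounds shown alone.

In a functional assay on HCT-116 cells (Homo sapiens) for inhibition, read by sulforhodamine B assay, with a stated time of 3 days (on this read-out lower numbers stand for stronger inhibition of growth and higher numbers for weaker inhibition of growth), compound 1 `O=C(/C=C/c1ccccc1Cl)c1ccc(OCc2ccccc2)cc1` gives 14900 nM, and compound 3 `COc1cccc(/C=C/C(=O)c2ccc(OCc3ccccc3)cc2)c1` gives 35400 nM. Compound 3 therefore holds the higher of the two actual numbers, and a 2.4-fold higher number from compound 1 to compound 3 (0.38 log units; beyond the scatter) is the step that separates them. Compound 2 `O=C(/C=C/c1ccc(F)cc1)c1ccc(OCc2ccccc2)cc1` is reported only as a limit, > 50000 nM.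

Compound 4 `COc1ccc(/C=C/C(=O)c2ccc(OCc3ccccc3)cc2)cc1` carries 4-methoxyphenyl in place of 3-methoxyphenyl on a double-bonded chain carbon bound to a double-bonded chain carbon. Going by the values given here, no measured step makes this exchange directly, so the evidence is indirect. Both measured departures from the 2-chlorophenyl of compound 1 raised the number: an at least 3.3-fold higher number from compound 1 to compound 2 (0.52 log units; beyond the scatter), alongside the step already given. The closest guide is compound 2, with its 4-fluorophenyl, and an at least 1.4-fold lower number from compound 2 to compound 3 (0.14 log units; that floor lies within the scatter) shows no separation from compound 3 beyond the scatter. On that basis, the change is expected to produce no shift beyond the scatter in this assay, and a report of only a limit remains quite possible. The expected step is a 1.1-fold higher number from compound 3 to compound 4 (0.03 log units; within the scatter). For compound 4 the estimated value is 38000 nM, with an expected range of 15000 nM to 60000 nM.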

Compound 4, concentration for 50% growth inhibition: 36900 nM
Compound 4: the middle estimate sits 1.0-fold (0.01 log units) above what was measured, and the stated range covers the measured number.
By their numbers in this assay, from the lowest: compound 1; then compounds 3 and 4 (each within the scatter of the next). At a limit, above all of these: compound 2.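

In this assay, 4-methoxyphenyl in place of 3-methoxyphenyl on a double-bonded chain carbon shows no separation on the shared core, with a 1.0-fold higher number from compound 3 to compound 4 (0.02 log units; within the scatter). The gap to the 2-chlorophenyl group therefore holds for both methoxyphenyl groups, with a 2.5-fold higher number from compound 1 to compound 4 (0.39 log units; beyond the scatter) alongside a 2.4-fold higher number from compound 1 to compound 3 (0.38 log units; beyond the scatter). Methoxy in place of fluoro on an aromatic carbon can be read only as an at least 1.3-fold lower number from compound 2 to compound 4 (0.13 log units; that floor lies within the scatter), a floor resting on a limit of the assay: the limit of > 50000 nM in this assay, at which 1 of the 4 values shown sits.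

The compounds shown leave open whether an amine or a carboxylic acid in place of the methoxy would separate from the two methoxyphenyl compounds, which so far give the same reading. Chloro appears at only one place in these compounds, so it also remains open whether the lower number of compound 1 belongs to the chloro group itself or to where it stands on the ring.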